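Aryl variation on a triazole amide series

The compounds below may be only part of what the source reports. "The series", "measured", "known", "first", "only" and "open" are said of these compounds alone.

Compound 1, `CC(C)(C)OC(=O)N1CCN(C(=O)c2cn(-c3ccc(Cl)c(C(F)(F)F)c3)nn2)CC1`: 12.3 nM
Compound 2, `CC(C)(C)OC(=O)N1CCN(C(=O)c2cn(-c3ccc(C(F)(F)F)cc3Cl)nn2)CC1`: 8.78 nM
Compound 3, `CC(C)(C)OC(=O)N1CCN(C(=O)c2cn(-c3ccc(C#N)cc3F)nn2)CC1`: 4.21 nM

All three compounds share the same core and were tested in an assay on HEK293 cells for agonist activity at Glucose-dependent insulinotropic receptor (Homo sapiens), read by a luciferase reporter, with a stated time of 24 h; a lower number here means that less compound is needed, a higher number that more compound is needed for the effect. Compound 3 gives the lowest number of the three in this assay: compound 2 and compound 1 both give higher numbers, and each of those gaps lies beyond the scatter. Within this small set, compound 3 therefore stands as the most potent measured compound.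

Compound 4, `CC(C)(C)OC(=O)N1CCN(C(=O)c2cn(-c3ccc(S(C)(=O)=O)cc3)nn2)CC1`, has not yet been measured. It differs from compound 3 in one place: 4-(methylsulfonyl)phenyl in place of 4-cyano-2-fluorophenyl on an aromatic nitrogen. Going by the values given here, no pair of measured compounds isolates this particular change, so no measured step can be read across. What the three measured compounds do show is that different aryl groups on the ring nitrogen all land within a narrow band.

On that basis compound 4 is expected to stay in the same band, with a moderate increase in the number that may or may not exceed the scatter; the estimated step is a 2.4-fold higher number from compound 3 to compound 4 (0.38 log units; beyond the scatter). The estimate for compound 4 in this assay is 10 nM, with a range from 3 nM to 40 nM.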

Compound 4, half-maximal effective concentration: 3.12 nM
Estimate against measurement, compound 4: 3.2-fold (0.51 log units) above; the measured number falls inside the stated range.
By their numbers in this assay, from the lowest: compounds 4 and 3 (each within the scatter of the next); then compounds 2 and 1 (each within the scatter of the next).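

In this assay, placing 4-(methylsulfonyl)phenyl in place of 4-cyano-2-fluorophenyl on the aromatic nitrogen gives a 1.3-fold lower number from compound 3 to compound 4 (0.13 log units; within the scatter), so this position takes the exchange without a shift that can be told from the scatter. Going by these compounds alone, this is the only step that changes a single place, and it gives the first direct reading at this position: the two aryl groups differ in their atoms and in their hydrogen-bond acceptor counts, yet compound 3 and compound 4 cannot be told apart in this measurement. No supporting data bear on why these two groups read alike.

Still open, on these data alone, is which feature of the aryl group matters, since the nitrile and the fluorine leave together and the methylsulfonyl group enters in a single step, and whether a carboxylic acid or an amine on the same phenyl ring would read the same way. As far as these compounds go, it also remains open whether this insensitivity to the aryl group would persist if another part of the shared core were changed.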